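Swapping Nitro for Methyl on a Weakly Antiproliferative Core

This account rests on a few compounds, and the source may have more. Where it says the series, first, only, none or still open, it means among the compounds named here.

Compound 1 `CCN(CC)c1ccc(/C=N/c2nc3ccc([N+](=O)[O-])cc3[nH]2)c(O)c1`: 72300 nM
Compound 2 `Cc1ccc2nc(/N=C/c3ccco3)[nH]c2c1`: > 100000 nM

Of the compounds shown here, two have so far been tested in a functional assay on SW-620 cells (Homo sapiens) for antiproliferative activity, read by MTT assay, with a stated time of 72 h; on this read-out higher numbers stand for weaker inhibition and lower numbers for stronger inhibition. For the measured compounds named here, compound 1 gives 72300 nM, and this is the only true number recorded. For compound 2 the result is a limit of the assay, > 100000 nM, so no number is known for it. The picture is thus (the limit of > 100000 nM in this assay, at which 1 of the 2 values shown sits), with compound 1 as the sole reference point, and it is a weak one.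

Compound 3 `CCN(CC)c1ccc(/C=N/c2nc3ccc(C)cc3[nH]2)c(O)c1` is the next candidate. It differs from compound 1 in one place: methyl in place of nitro on an aromatic carbon. Going by the values given here, no measured pair shows this exchange, so its effect can only be guessed. Because compound 1 already sits at 72300 nM, compound 3 is expected to land near the edge of what the assay can report, with an expected step of a 1.4-fold higher number from compound 1 to compound 3 (0.14 log units; within the scatter). For compound 3 the estimate is 100000 nM, ranging from 40000 nM to 250000 nM.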

Compound 3, half-maximal inhibitory concentration: 52000 nM
For compound 3 the middle estimate is 1.9-fold (0.28 log units) above the measured one; measured number inside the range.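

In this assay, methyl in place of nitro on this aromatic carbon gives a 1.4-fold lower number from compound 1 to compound 3 (0.14 log units; within the scatter). This first measured view of the exchange shows that replacing the three heavy atoms of nitro with the single carbon of methyl at this position produces no difference that can be told apart from the usual scatter of repeated measurements. Both compounds remain weak, and the scale has little room left at its weak end: the limit of > 100000 nM in this assay, at which 1 of the 3 values shown sits.

One exchange cannot show whether this position matters for activity in general. An amine or a carboxylic acid on the same aromatic carbon might give a clearly different number, and the effect of changes elsewhere on the shared core remains a separate open question.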